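The source may hold more compounds than are shown below. What is called first, only, known or untested is meant among the compounds shown, and "the series" means these compounds.

Compounds 1 and 2 share one core and differ only in the ring that hangs from the carbon with a double bond to nitrogen. Compound 1 `O=C(N/N=C/c1ccc(O)cc1)c1cccnc1Nc1cccc(C(F)(F)F)c1` gives 59.5% in a functional assay on the whole organism (strain Wistar) for inhibition, with Rattus norvegicus as the target, read by paw edema, with a stated time of 3 h, at a dose of 10 mg/kg by the intraperitoneal route (a lower number here means less inhibition, a higher number more inhibition at the dose given (going by the name of the read-out)), and compound 2 `COc1cccc(/C=N/NC(=O)c2cccnc2Nc2cccc(C(F)(F)F)c2)c1` gives 30.3%. Going by the values given here, the single step on record, a number 29.2 percentage points lower from compound 1 to compound 2 (beyond the scatter), shows that swapping the ring at this position can shift the read-out by a modest amount. Compound 2 therefore stands lowest of the two numbers, with compound 1 the higher by a margin beyond the scatter.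

Compound 3 `O=C(N/N=C/c1ccncc1)c1cccnc1Nc1cccc(C(F)(F)F)c1` has not yet been measured in this assay. It differs from compound 2 in one place: pyridin-4-yl in place of 3-methoxyphenyl on a carbon with a double bond to nitrogen. Among the compounds with values here, no measured step matches this exact change; the one step available only indicates the scale on which this position responds. Given that uncertainty, compound 3 is expected at 40%, in a range from 20% to 60%. The step of a number 9.7 percentage points higher from compound 2 to compound 3 (within the scatter) is thus estimated as a small rise that may well fall within the scatter.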

Compound 3, a percentage reported as inhibition, in the whole organism at one dose (the size of the read-out at that dose, not a potency): 54.9%
Beside the measured number, compound 3's estimate is 14.9 percentage points below it, within the range that was stated.
By their numbers in this assay, from the lowest: compound 2; then compounds 3 and 1 (each within the scatter of the next).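

In this assay, the step of a number 24.6 percentage points higher from compound 2 to compound 3 (beyond the scatter) shows that this position can hold a ring containing a nitrogen atom, pyridin-4-yl, and give a clearly different read-out from the 3-methoxyphenyl ring it replaces. The step of a number 4.6 percentage points lower from compound 1 to compound 3 (within the scatter) places pyridin-4-yl level with 4-hydroxyphenyl, so among these three compounds a hydroxyl-bearing phenyl ring is not the only ring that reaches this level, and the earlier contrast between compound 1 and compound 2 now has a second point of reference. No measurement here explains why 3-methoxyphenyl stands apart from the other two rings.

Since 4-hydroxyphenyl and 3-methoxyphenyl differ in both the group they carry and where it sits, the compounds shown cannot say which of those two differences matters, and a 4-methoxyphenyl or 3-hydroxyphenyl ring would help to separate them. From the compounds shown here alone, how the read-out would respond to a phenyl ring carrying an amine or a carboxylic acid, or to a longer chain on this carbon, also remains open.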